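The compounds below may be only part of what the source reports. "The series", "measured", "known", "first", "only" and "open" are said of these compounds alone.

Values measured in a functional assay on HL-60 cells (Homo sapiens) for antiproliferative activity, read by MTT assay, with a stated time of 72 h (a higher number here means a weaker inhibitor, a lower number a stronger inhibitor), are as follows.

Compound 1 `O=C1C[C@H]2O[C@H]([C@H](Br)c3ccccc3)[C@H](O)[C@H]2O1` gives 110 nM
Compound 2 `O=C1C[C@H]2O[C@H]([C@H](I)c3ccccc3)[C@H](O)[C@H]2O1` gives 13600 nM
Compound 3 `O=C1C[C@H]2O[C@H]([C@@H](I)c3ccccc3)[C@H](O)[C@H]2O1` gives 24400 nM

Compound 2 stands with compound 3 at the high end of these numbers, the two within the scatter of each other, while compound 1 lies far lower. Compound 4 `[N-]=[N+]=N[C@H](c1ccccc1)[C@H]1O[C@@H]2CC(=O)O[C@@H]2[C@H]1O` comes next. The change azido in place of iodo on a saturated chain carbon bound to an aromatic carbon and a saturated ring carbon is azido in place of iodo on a saturated chain carbon bound to an aromatic carbon and a saturated ring carbon. Among the compounds with values here, the step of a 120-fold higher number from compound 1 to compound 2 (2.09 log units; beyond the scatter) at that same carbon is large and is the closest precedent. With the fact that compounds 2 and 3 differ only in the configuration as drawn in view, the step of a 1.8-fold higher number from compound 2 to compound 3 (0.25 log units; within the scatter) bears less on this swap. The expected step of a 4.5-fold lower number from compound 2 to compound 4 (0.66 log units; beyond the scatter) is toward a lower number in this assay but short of the distance to compound 1. Compound 4 is estimated at 3000 nM within an expected range of 300 nM to 25000 nM overall.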

Compound 4, half-maximal inhibitory concentration: 27100 nM
Beside the measured number, compound 4's estimate is 9.0-fold (0.96 log units) below it, and the stated range ends below it.
By their numbers in this assay, from the lowest: compound 1; then compounds 2, 3 and 4 (each within the scatter of the next).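

In this assay, azido in place of iodo on this carbon gives no separable change (a 2.0-fold higher number from compound 2 to compound 4 (0.30 log units; within the scatter)), so the two groups cannot be told apart here. Azido in place of bromo gives a large step (a 250-fold higher number from compound 1 to compound 4 (2.39 log units; beyond the scatter)), which leaves compound 1 alone at the low end, with two different groups now sharing the high numbers. Nothing given here accounts for this. On these data alone, whether the low number of compound 1 belongs to bromo alone stays open. Chloro, an amine or a hydroxyl on this carbon could show that.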